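Moving the halogen on the amide's aryl ring: chloro to bromo

The source may hold more compounds than are shown below. What is called first, only, known or untested is meant among the compounds shown, and "the series" means these compounds.

Of the compounds shown here, two in one series have been tested in a functional assay on SK-BR-3 cells (Homo sapiens) for antiproliferative activity, read by MTT assay, with a stated time of 72 h; a higher number here means a weaker inhibitor, a lower number a stronger inhibitor. Compound 1 `CCc1ccc(C(=O)Nc2ccc3nc(N4CCN(CC)CC4)cc(C)c3c2)cc1` gives 9850 nM. Among the measured compounds shown here, compound 2 `CCN1CCN(c2cc(C)c3cc(NC(=O)c4ccc(Cl)cc4)ccc3n2)CC1` gives 3020 nM, the lowest of the two numbers; the only step to it, a 3.3-fold lower number from compound 1 to compound 2 (0.51 log units; beyond the scatter), is a modest move that still lies beyond the scatter. Compound 3 `CCN1CCN(c2cc(C)c3cc(NC(=O)c4cccc(Br)c4)ccc3n2)CC1` has not yet been measured. It differs from compound 2 at the amide end: 3-bromophenyl in place of 4-chlorophenyl on a carbonyl carbon. For the measured compounds named here, no measured step swaps one halogenated ring for another, so the one step available, from compound 1 to compound 2, bears on this only loosely, showing that a change on this ring can shift the number by a modest amount. The change to compound 3 is therefore expected to move the number only a little, if at all, and in either direction, with a 1.3-fold higher number from compound 2 to compound 3 (0.12 log units; within the scatter) as the estimated step. Compound 3 is estimated at 4000 nM, within a range of 1500 nM to 12000 nM.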

Compound 3, half-maximal inhibitory concentration: 13300 nM
Compound 3: middle estimate off by 3.3-fold (0.52 log units), on the low side; measured number outside the range, above it.
By their numbers in this assay, from the lowest: compound 2; then compounds 1 and 3 (each within the scatter of the next).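

In this assay the swap of 4-chlorophenyl for 3-bromophenyl on a carbonyl carbon gives a 4.4-fold higher number from compound 2 to compound 3 (0.64 log units; beyond the scatter) and so is not a neutral exchange, even though both groups have the same heavy-atom count and both carry one halogen. Having a halogen on this ring is also not enough for a lower number, since a 1.4-fold higher number from compound 1 to compound 3 (0.13 log units; within the scatter) leaves compound 3 no different from the ethyl-bearing compound 1, and compound 2 alone stands apart. No measurement here explains why these two halogenated rings differ. Compound 3 changes both the halogen and where it sits, so the compounds shown cannot tell which of the two changes matters. From the compounds shown here alone, how a ring carrying a methoxy group, a nitrile or an amine would read also remains open.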